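Removing the methoxy from the aryl ring of compound 2

A few compounds are considered here, and "the series" means these few. Any claim that something is new, unique, unknown or untested is made for them only; others in the source may bear on it.

The series shares one core; compound 1 `OC(CCn1nc2c(Br)c(Br)c(Br)c(Br)c2n1)c1ccc(F)cc1` carries 4-fluorophenyl and compound 2 `COc1cccc(C(O)CCn2nc3c(Br)c(Br)c(Br)c(Br)c3n2)c1` carries 3-methoxyphenyl on the saturated chain carbon that bears the hydroxyl. In a functional assay on CCRF-CEM cells (Homo sapiens) for antiproliferative activity, read by MTT assay, with a stated time of 24 h, tested at 50 uM (a lower number here means a stronger effect, a higher number a weaker effect of the compound at the concentration tested), compound 1 gives 46% and compound 2 gives 58%. Going by the values given here, the one step available, a number 12 percentage points higher from compound 1 to compound 2 (beyond the scatter), is the only guide to how the aryl group matters here. Compound 2 thus stands highest of the two numbers, with compound 1 as its nearest neighbour and a weaker read-out for compound 2 than for compound 1.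

Compound 3 `OC(CCn1nc2c(Br)c(Br)c(Br)c(Br)c2n1)c1ccccc1` is the unmeasured neighbour. The change is hydrogen in place of methoxy on an aromatic carbon. Among the compounds with values here, no measured step removes a methoxy; the step from compound 1 to compound 2 only exchanges one substituted phenyl for another, and it was modest. Taking the methoxy away is expected to move the number part of the way back toward compound 1, a step of a number 7 percentage points lower from compound 2 to compound 3 (within the scatter) in this assay that may itself fall within the scatter. Compound 3 is therefore expected to give about 51%, with a likely range from 38% to 64%.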

Compound 3, a percentage reported as activity, at one concentration (the size of the read-out at that concentration, not a potency): 66%
Beside the measured number, compound 3's estimate is 15 percentage points below it, and the stated range ends below it.
By their numbers in this assay, from the lowest: compound 1; then compounds 2 and 3 (each within the scatter of the next).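

In this assay, the methoxy-to-hydrogen change gives a number 8 percentage points higher from compound 2 to compound 3 (within the scatter) and so does not separate 3-methoxyphenyl from phenyl at this position. The fluoro-to-hydrogen change gives a number 20 percentage points higher from compound 1 to compound 3 (beyond the scatter) and is the step that counts here, so among these three aryl groups only the 4-fluorophenyl of compound 1 stands apart, with the lower number and the stronger effect at the concentration tested. Nothing at hand accounts for a step beyond the scatter with fluoro and one within it with methoxy.

Still open, from the compounds shown here alone, is whether the separation of compound 1 belongs to fluoro itself or to the aromatic carbon that carries it, which a fluoro on the aromatic carbon bearing the methoxy in compound 2 would help settle. Also open, going by these compounds, is how a chloro group, an amine or a carboxylic acid on the aryl ring would read at this single concentration, and whether a longer chain between the hydroxyl-bearing carbon and the shared core would leave the order of these aryl groups in place.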